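Methyl Ester to Ethyl Amide on the Shared Core

A few compounds are considered here, and "the series" means these few. Any claim that something is new, unique, unknown or untested is made for them only; others in the source may bear on it.

Of the compounds shown here, three built on one shared core have been measured. Compound 1 `COc1ccc(Cl)cc1S(=O)(=O)Nc1cncc(-c2ccncc2)c1` gives 73 nM in an assay on isolated protein for inhibition of alkaline phosphatase, tissue-nonspecific isozyme (Homo sapiens); on this read-out higher numbers stand for weaker inhibition and lower numbers for stronger inhibition. Compound 2 `COc1ccc(Cl)cc1S(=O)(=O)Nc1cncc(C(N)=O)c1` gives 16 nM in this assay, reached by a 4.6-fold lower number from compound 1 to compound 2 (0.66 log units; beyond the scatter). Compound 3 `COC(=O)c1cncc(NS(=O)(=O)c2cc(Cl)ccc2OC)c1` gives 65 nM in this assay, the second highest of the three numbers; it sits close to compound 1, since a 1.1-fold lower number from compound 1 to compound 3 (0.05 log units; within the scatter), and farthest from compound 2, since a 4.1-fold higher number from compound 2 to compound 3 (0.61 log units; beyond the scatter).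

Compound 4 `CCNC(=O)c1cncc(NS(=O)(=O)c2cc(Cl)ccc2OC)c1` is the next step from compound 3. The change is ethylamino in place of methoxy on a carbonyl carbon. For the measured compounds named here, the step most directly bearing on it is the one between compound 2 and compound 3, where a 4.1-fold higher number from compound 2 to compound 3 (0.61 log units; beyond the scatter); compound 4 goes part of the way back by restoring a nitrogen on the carbonyl carbon, now carrying an ethyl group rather than two hydrogens. The step of a 4.6-fold lower number from compound 1 to compound 2 (0.66 log units; beyond the scatter) also shows that a carbamoyl on that aromatic carbon gives the lowest number of the set. Going by the values given here, no measured pair separates a primary amide from an ethyl amide, so the size of the return is uncertain.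

Compound 4 is therefore expected to show a 2.3-fold lower number from compound 3 to compound 4 (0.37 log units; beyond the scatter), a modest move beyond the scatter toward lower numbers. Compound 4 is estimated at 28 nM, within a range of 9 nM to 85 nM.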

Compound 4, half-maximal inhibitory concentration: 193 nM
Compound 4: the middle estimate sits 6.9-fold (0.84 log units) below what was measured; measured number above the stated range.
By their numbers in this assay, from the lowest: compound 2; then compounds 3 and 1 (each within the scatter of the next); then compound 4.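

For the compounds shown here, the result separates two things that the earlier compounds left joined. Restoring a nitrogen on the carbonyl carbon does not by itself recover the low number of compound 2, as the methoxy to ethylamino change gives a 3.0-fold higher number from compound 3 to compound 4 (0.47 log units; beyond the scatter) and so moves away from compound 2 rather than toward it, while the ethyl group on the amide-type nitrogen accounts for the largest step in the set, with a 12-fold higher number from compound 2 to compound 4 (1.08 log units; beyond the scatter) in the one comparison that isolates it. The ethylcarbamoyl group also ends up behind the pyridin-4-yl group on the same aromatic carbon, with a 2.6-fold higher number from compound 1 to compound 4 (0.42 log units; beyond the scatter) on that comparison, so the primary amide of compound 2 gives the lowest number and the ethyl amide of compound 4 the highest, and an amide at this place is not enough for a low number. No evidence is available to explain this rise.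

From the compounds shown here alone, whether a single methyl on that nitrogen would fall nearer compound 2 or compound 4 remains open, as does whether a longer chain such as propyl would raise the number further. Going by these compounds, how a carboxylic acid or a dimethylamide at this place would read in this assay also remains open.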